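The source may report more compounds than this note shows. Statements on the series, on what has been measured and on what is new or still open speak of the compounds shown alone.

Notes on the series, read in a functional assay on NCI-H460 cells (Homo sapiens) for inhibition, read by CCK-8 assay, with a stated time of 72 h, tested at 1 uM; on this read-out higher numbers stand for more inhibition of growth at the one concentration tested and lower numbers for less inhibition of growth. Among the measured compounds shown here, compound 2 (`CN(C)C(=O)c1cc2cnc(Nc3ccc(NC(=O)C4(C(=O)Nc5ccccc5F)CC4)cc3)nc2n1C1CCCC1`) gives 28.2%, the lower of the two numbers so far, and compound 1 (`CN(C)C(=O)c1cc2cnc(Nc3ccc(NC(=O)C4(C(=O)Nc5cccc(F)c5)CC4)cc3)nc2n1C1CCCC1`) gives 45.1%. Compound 3 (`CN(C)C(=O)c1cc2cnc(Nc3ccc(NC(=O)C4(C(=O)Nc5cccc(Cl)c5)CC4)cc3)nc2n1C1CCCC1`) is still unmeasured. Its difference from compound 2 is 3-chlorophenyl in place of 2-fluorophenyl on an amide-type nitrogen.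

For the measured compounds named here, only one measured step bears on this change, a number 16.9 percentage points lower from compound 1 to compound 2 (beyond the scatter), a modest drop on going from 3-fluorophenyl to 2-fluorophenyl at that same nitrogen. Compound 3 leaves 2-fluorophenyl behind, as compound 1 does, and carries 3-chlorophenyl where compound 1 carries 3-fluorophenyl. Going by the values given here, no measured pair shows what 3-chlorophenyl gives in place of 3-fluorophenyl, so this expectation rests on one step alone. A rise of about the size of that step, beyond the scatter, is therefore expected in this assay, which would bring the number back towards that of compound 1, measured at 45.1%. The estimated change is a number 15.8 percentage points higher from compound 2 to compound 3 (beyond the scatter). The expected value for compound 3 is 44%, with an estimated range of 28% to 60%.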

Compound 3, percent growth inhibition at one concentration: 44%
Estimate against measurement, compound 3: no gap at the digits printed; the measured number falls inside the stated range.
By their numbers in this assay, from the lowest: compound 2; then compounds 3 and 1 (each within the scatter of the next).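

In this assay, the step of a number 1.1 percentage points lower from compound 1 to compound 3 (within the scatter) gives the first direct read on the halogen itself: with 3-chlorophenyl in place of 3-fluorophenyl on the amide-type nitrogen, chloro and fluoro cannot be told apart on this read-out. The step of a number 15.8 percentage points higher from compound 2 to compound 3 (beyond the scatter) shows that a second group also stands clear of 2-fluorophenyl, so among the three aryl groups shown, only 2-fluorophenyl goes with a number beyond the scatter from the other two, and no compound here goes against this. Nothing available explains this difference between the aryl groups.

As far as these compounds go, it remains open whether chloro in place of fluoro on the 2-fluorophenyl of compound 2 would also leave the number within the scatter, which would show whether the halogen is as interchangeable there as it is in compound 1 and compound 3. Also open is what an unsubstituted phenyl, a methoxy group in place of the halogen or a pyridine ring would give on this nitrogen, since every aryl group shown carries a single halogen.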